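The source may hold more compounds than are shown below. What is called first, only, known or untested is meant among the compounds shown, and "the series" means these compounds.

In a functional assay on NCI-H226 cells (Homo sapiens) for inhibition, read by MTT assay, with a stated time of 72 h (a lower number here means a stronger inhibitor of growth, a higher number a weaker inhibitor of growth), compound 3 `COC(=O)c1nc(C(C)C)n(-c2ccc(F)cc2)n1` gives 6170 nM. Compound 1 `COC(=O)c1nc(C)n(-c2ccccc2C(F)(F)F)n1` gives 6130 nM in this assay, and the two numbers lie within the scatter of each other, so compound 3 cannot be separated from compound 1 on the numbers shown; these are the only two numbers given. Compound 2 `COC(=O)c1nc(C)n(-c2ccc(OC)cc2)n1` reaches only a limit in this assay, > 100000 nM, which is not a number. That reading is the limit of > 100000 nM in this assay, at which 1 of the 3 values shown sits. Compound 4 `COC(=O)c1nc(-c2ccc[nH]2)n(-c2ccc(F)cc2)n1` has not yet been measured. It differs from compound 3 in one place: 1H-pyrrol-2-yl in place of isopropyl on an aromatic carbon. Among the measured compounds shown here, no measured pair shows the effect of such a change, and there is no ground for a step in either direction beyond the usual scatter. Compound 4 is expected to give about 5000 nM in this assay, within a range from 1500 nM to 20000 nM. The step this estimate means, a 1.2-fold lower number from compound 3 to compound 4 (0.09 log units; within the scatter), is expected to stay inside the scatter.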

Compound 4, concentration for 50% growth inhibition: 72000 nM
Compound 4: middle estimate off by 14-fold (1.16 log units), on the low side; the whole stated range lies below it.
By their numbers in this assay, from the lowest: compounds 1 and 3 (each within the scatter of the next); then compound 4. At a limit, above all of these: compound 2.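

In this assay, the position on the shared core that carries isopropyl in compound 3 proves sensitive to the group placed there: 1H-pyrrol-2-yl in place of isopropyl gives a 12-fold higher number from compound 3 to compound 4 (1.07 log units; beyond the scatter), the only step shown between compounds that differ in one place. This single change brings in a larger group, a five-membered aromatic ring and a hydrogen-bond donor together, so this one pair cannot separate these features. Nothing measured here offers a cause for the step.

Going by these compounds, it remains open whether a phenyl or cyclopropyl group at this position would stay within the scatter of compound 3 or give a weaker inhibitor of growth, as 1H-pyrrol-2-yl does. Also open, on these data alone, is whether an amine there, or a carboxylic acid in place of the methoxycarbonyl group, would change the number.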